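The source may report more compounds than this note shows. Statements on the series, on what has been measured and on what is new or still open speak of the compounds shown alone.

Three related amides have been measured in a functional assay on HeLa cells (Homo sapiens) for antiproliferative activity, read by sulforhodamine B assay, with a stated time of 48 h; a lower number here means a stronger inhibitor of growth, a higher number a weaker inhibitor of growth. Compound 1 `COc1ccc(Cn2cc(CNC(=O)c3cn(-c4ccccc4)nc3-c3ccccc3)nn2)cc1OC` gives 10800 nM. Compound 2 `O=C(NCc1cn(Cc2ccc(F)cc2)nn1)c1cn(-c2ccccc2)nc1-c1ccc(Cl)cc1` gives 2800 nM. Compound 3 `COc1ccc(Cn2cc(CNC(=O)c3cn(-c4ccccc4)nc3-c3ccc(Cl)cc3)nn2)cc1` gives 1400 nM, the lowest of the three numbers; compound 2 lies within the usual scatter of it, while compound 1 lies clearly higher. Among the measured compounds shown here, the only single-point step measured so far is a 2.0-fold lower number from compound 2 to compound 3 (0.30 log units; within the scatter). Compound 4 `COc1ccc(Cn2cc(CNC(=O)c3cn(-c4ccccc4)nc3-c3ccc(Cl)cc3)nn2)cc1OC` differs from compound 3 by methoxy in place of hydrogen on an aromatic carbon. For the measured compounds named here, no measured step adds a methoxy group in this way, so the expectation rests loosely on compound 1, whose higher value 10800 nM also carries two methoxy groups but lacks the chlorine, which makes it an unclean comparison. A modest weakening is therefore expected, a step of a 1.8-fold higher number from compound 3 to compound 4 (0.25 log units; within the scatter) in this assay. Compound 4 is estimated at 2500 nM, with a range from 800 nM to 8000 nM.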

Compound 4, concentration for 50% growth inhibition: 200 nM
The estimate for compound 4 lay 13-fold (1.10 log units) above the measured number, and the stated range ends above it.
By their numbers in this assay, from the lowest: compound 4; then compounds 3 and 2 (each within the scatter of the next); then compound 1.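

In this assay a second methoxy, turning 4-methoxyphenyl into 3,4-dimethoxyphenyl, gives a 7.0-fold lower number from compound 3 to compound 4 (0.85 log units; beyond the scatter) and so shows a clear response at this carbon, which the earlier change from fluoro to methoxy, within the scatter, did not show. Replacing 4-fluorophenyl with 3,4-dimethoxyphenyl gives a 14-fold lower number from compound 2 to compound 4 (1.15 log units; beyond the scatter) and chloro in place of hydrogen on an aromatic carbon, with both methoxy groups present, gives a 54-fold lower number from compound 1 to compound 4 (1.73 log units; beyond the scatter) so the chloro matters as well. Nothing available explains why the added methoxy has this effect. Going by these compounds, whether ethoxy, hydroxyl or an amine on this carbon would give a similar number remains open.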